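Ether groups on the saturated ring carbon: working notes

The compounds below may be only part of what the source reports. "The series", "measured", "known", "first", "only" and "open" are said of these compounds alone.

Measured so far:
compound 1 `Cc1nn(-c2ncnc3nc[nH]c23)c2c1C(C(=O)N(C)c1nccs1)CC(=O)N2`: 3300 nM
compound 2 `CCCCCCCCOC1CC(=O)Nc2c1c(C)nn2-c1ncnc2nc[nH]c12`: 388 nM

In a functional assay on HEK293 cells for agonist activity at G-protein coupled receptor 39 (Homo sapiens), read by scintillation proximity assay and inositol phosphate accumulation, with a stated time of 75 min (a lower number here means that less compound is needed, a higher number that more compound is needed for the effect), compound 1 gives 3300 nM, the highest of the two numbers measured. Its nearest neighbour is compound 2 with 388 nM. That gap, an 8.5-fold lower number from compound 1 to compound 2 (0.93 log units; beyond the scatter), lies beyond the scatter.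

Compound 3 `Cc1nn(-c2ncnc3nc[nH]c23)c2c1C(OCc1ccc(C#N)cc1)CC(=O)N2` has not yet been measured in this assay. It differs from compound 1 as follows: (4-cyanobenzyl)oxy in place of methyl(1,3-thiazol-2-yl)carbamoyl on a saturated ring carbon. Within the data shown here, the only measured step that bears on this change is an 8.5-fold lower number from compound 1 to compound 2 (0.93 log units; beyond the scatter), where octyloxy replaced the same methyl(1,3-thiazol-2-yl)carbamoyl group on the same saturated ring carbon. Among the measured compounds shown here, compound 3 likewise exchanges that carbamoyl for an oxygen-linked group, but the entering group is (4-cyanobenzyl)oxy rather than octyloxy, and no measured pair shows what this difference in the entering group does. The change is therefore expected to move the number in the same direction as the octyloxy replacement did, with less certainty about its size. The expected step is a 5.1-fold lower number from compound 1 to compound 3 (0.71 log units; beyond the scatter). For compound 3 the estimate in this assay is 650 nM, with a range of 200 nM to 2200 nM.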

Compound 3, half-maximal effective concentration: 60 nM
The estimate for compound 3 lay 11-fold (1.03 log units) above the measured number; the measured number lies below the stated range.
By their numbers in this assay, from the lowest: compound 3; then compound 2; then compound 1.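

In this assay, the saturated ring carbon accepts an oxygen-linked group carrying an aromatic ring as well as one carrying a long chain, and a 55-fold lower number from compound 1 to compound 3 (1.74 log units; beyond the scatter) is the largest step seen so far at this position, with (4-cyanobenzyl)oxy entering in place of methyl(1,3-thiazol-2-yl)carbamoyl. The earlier pair could not show that the number depends on what lies beyond the ether oxygen, whereas a 6.5-fold lower number from compound 2 to compound 3 (0.81 log units; beyond the scatter) shows this directly, with 4-cyanophenyl in place of heptyl on the saturated chain carbon bound to that oxygen, so the octyloxy step does not set the size of the change for every ether. Nothing available explains either step, and the numbers record only what accompanies each exchange of groups.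

The compounds shown do not separate the contribution of the nitrile from that of the aromatic ring, which a plain benzyloxy group, or a methoxy group or a chlorine in place of the nitrile, would address. They also leave open whether the ether oxygen itself is needed, as a benzyl group joined directly through carbon or a benzylamine link at the same ring carbon would show.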